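Aryl change from compound 2 to compound 3

The compounds below may be only part of what the source reports. "The series", "measured", "known", "first", "only" and "open" are said of these compounds alone.

In a functional assay on MCF7 cells (Homo sapiens) for cytotoxicity, read by MTT assay, with a stated time of 72 h (on this read-out higher numbers stand for weaker inhibition and lower numbers for stronger inhibition), compound 1 (`COc1ccc(/C=C/C(=O)Nc2cc3c(Nc4ccc(F)c(Cl)c4)ncnc3cc2O[C@H]2CCOC2)c(OC)c1`) gives 28600 nM and compound 2 (`N#Cc1ccc(/C=C/C(=O)Nc2cc3c(Nc4ccc(F)c(Cl)c4)ncnc3cc2O[C@H]2CCOC2)cc1`) gives 9830 nM as the lower of the two numbers. Compound 3 (`COc1ccc(/C=C/C(=O)Nc2cc3c(Nc4ccc(F)c(Cl)c4)ncnc3cc2O[C@H]2CCOC2)c(OC)c1OC`) has not yet been measured. It carries 2,3,4-trimethoxyphenyl in place of 4-cyanophenyl on a double-bonded chain carbon bound to a double-bonded chain carbon. For the measured compounds named here, one measured step bears on this change: a 2.9-fold lower number from compound 1 to compound 2 (0.46 log units; beyond the scatter) with 4-cyanophenyl in place of 2,4-dimethoxyphenyl, modest but beyond the scatter. The present change also involves 4-cyanophenyl but removes it, so a modest rise is expected on the strength of that single step. The expected step in this assay is a 2.4-fold higher number from compound 2 to compound 3 (0.39 log units; beyond the scatter) as an estimate. For compound 3 the estimated value is 24000 nM with an expected range from 10000 nM to 58000 nM in this assay.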

Compound 3, half-maximal inhibitory concentration: 4650 nM
Estimate against measurement, compound 3: 5.2-fold (0.71 log units) above; the measured number lies below the stated range.
By their numbers in this assay, from the lowest: compound 3; then compound 2; then compound 1.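

In this assay, this position on a double-bonded chain carbon bound to a double-bonded chain carbon does not sort simply into methoxy-bearing and nitrile-bearing aryl groups: 2,3,4-trimethoxyphenyl in place of 4-cyanophenyl gives a 2.1-fold lower number from compound 2 to compound 3 (0.33 log units; beyond the scatter), so 4-cyanophenyl now falls between two methoxy-bearing rings. Methoxy in place of hydrogen on an aromatic carbon gives a 6.2-fold lower number from compound 1 to compound 3 (0.79 log units; beyond the scatter), which shows that the read-out depends on the methoxy pattern and not merely on methoxy being present. No measured evidence on hand accounts for either step.

The compounds shown leave open how a ring carrying an amine or a carboxylic acid would compare at this position. They also leave open whether a saturated ring in place of the aryl group would keep the order seen in this assay.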